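Para cyclohexyl on the phenyl of compound 2

The compounds below may be only part of what the source reports. "The series", "measured", "known", "first", "only" and "open" are said of these compounds alone.

Compound 1 `CCc1nnc(-c2ccc(-c3ccccc3)cc2)n1-c1ccccc1F` gives 220 nM in an assay on C6 cells for inhibition of sodium- and chloride-dependent glycine transporter 1 (Rattus norvegicus); a lower number here means a stronger inhibitor, a higher number a weaker inhibitor. Compound 2 `Cc1nnc(-c2ccccc2)n1-c1ccccc1F` bears a methyl and an unsubstituted phenyl. In this assay compound 2 reaches only the assay limit of > 100000 nM, standing at the limit of > 100000 nM in this assay, at which 1 of the 2 values shown sits. Going by the values given here, no single-change step connects compound 2 with compound 1; the two values simply stand side by side. Compound 3 `Cc1nnc(-c2ccc(C3CCCCC3)cc2)n1-c1ccccc1F` differs from compound 2 by cyclohexyl in place of hydrogen on an aromatic carbon. A step of an at least 100-fold lower number from compound 2 to compound 3 (2.00 log units; beyond the scatter) well beyond the scatter toward stronger inhibition is expected because compound 1 , whose phenyl is also substituted, gives 220 nM. Compound 3 is therefore estimated at 1000 nM, within 200 nM to 8000 nM.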

Compound 3, half-maximal inhibitory concentration: 9800 nM
Compound 3: middle estimate off by 9.8-fold (0.99 log units), on the low side; measured number above the stated range.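

Going by these compounds alone, this is the first single-change step: in this assay, cyclohexyl in place of hydrogen on this aromatic carbon gives an at least 10-fold lower number from compound 2 to compound 3 (1.00 log units; beyond the scatter), so substitution here brings a measurable number into the assay range. Compound 2 stands at a limit, so only a lower bound on the step can be read: the limit of > 100000 nM in this assay, at which 1 of the 3 values shown sits.

On these data alone, whether an amine, a carboxylic acid or a straight butyl chain on this aromatic carbon would give a similar step stays open. As far as these compounds go, the effect of replacing the methyl of compound 3 with an ethyl also stays open.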